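The compounds below may be only part of what the source reports. "The series", "measured", "known", "first", "only" and "open" are said of these compounds alone.

Working notes on the series. Compound 3 `O=C(O)c1cccc(C2=C(c3cc(Cl)ccc3OCc3ccccc3)CCC2)c1` carries chloro on its outer aromatic ring and an unsubstituted benzyloxy group. In an assay on isolated protein for inhibition of prostaglandin E2 receptor EP3 subtype (Homo sapiens) (a lower number here means a stronger inhibitor, a higher number a weaker inhibitor), compound 3 gives < 3170 nM, which is a limit of the assay and not a number. Compound 1 `O=C(O)c1cccc(C2=C(c3cc(Br)ccc3OCc3ccc(F)cc3)CCC2)c1` is the bromo analogue with a fluoro on the benzyloxy ring; in this assay compound 1 gives < 3170 nM, again only a limit. Compound 2 `O=C(O)c1cccc(C2=C(c3cc(Br)ccc3OCc3ccc(Cl)cc3)CCC2)c1` carries chloro on the benzyloxy ring instead; in this assay compound 2 gives < 3170 nM, also a limit. All three values sit at the limit of < 3170 nM in this assay, at which 3 of the 3 values shown sit, so the step that the two limits leave unreadable from compound 1 to compound 2, chloro in place of fluoro on an aromatic carbon, cannot be read.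

Compound 4 `O=C(O)c1cccc(C2=C(c3cc(Br)ccc3OCc3ccccc3)CCC2)c1` differs from compound 3 by bromo in place of chloro on an aromatic carbon. Going by the values given here, the only measured step does not resolve any size, and compound 1 and compound 2 both carry bromo yet both rest at the limit of < 3170 nM in this assay, at which 3 of the 3 values shown sit. Compound 4 is therefore expected near 600 nM, within 60 nM to 3000 nM, most probably reported again only as a limit. The step that the limit leaves unreadable from compound 3 to compound 4 is expected to stay within the scatter.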

Compound 4, half-maximal inhibitory concentration: < 3170 nM
Compound 4: no number, only a limit; the forecaster's own chance of this, stated with the estimate: 85%; the middle value does not contradict the limit.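

Going by these compounds alone, compound 4 again gives only a limit in this assay, so no step from compound 1, compound 2 or compound 3 to compound 4 can be read: the limit of < 3170 nM in this assay, at which 4 of the 4 values shown sit. The compounds shown leave open whether exchanging fluoro, chloro, bromo or hydrogen changes inhibition at all.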